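The source may hold more compounds than are shown below. What is called first, only, known or untested is meant among the compounds shown, and "the series" means these compounds.

Compound 3 `COc1cccc(Oc2ccc3c(NCCCNCc4ccco4)ccnc3c2)c1` gives 317 10^-6 cm/s in an ADME assay for permeability, using PAMPA, with a stated time of 30 min, at pH 7.4 (on this read-out lower numbers stand for lower permeability and higher numbers for higher permeability), level with compound 1 `Fc1ccc(Oc2ccc3c(NCCCNCc4ccco4)ccnc3c2)cc1` at 317 10^-6 cm/s; together these are the highest of the three numbers shown, while compound 2 `FC(F)(F)c1ccc(-c2ccc3c(NCCCNCc4ccco4)ccnc3c2)cc1` gives 237 10^-6 cm/s. The measured steps of a 1.3-fold lower number from compound 1 to compound 2 (0.13 log units; within the scatter), no change at the digits printed from compound 1 to compound 3 (within the scatter) and a 1.3-fold higher number from compound 2 to compound 3 (0.13 log units; within the scatter) all lie within the scatter. Compound 4 `Clc1ccc(Oc2ccc3c(NCCCNCc4ccco4)ccnc3c2)cc1` differs from compound 3 by 4-chlorophenyl in place of 3-methoxyphenyl on an oxygen on an aromatic ring. The step that bears on this most directly is the earlier exchange of a ring on the same oxygen, no change at the digits printed from compound 1 to compound 3 (within the scatter), and the two other steps were no larger. Compound 4 is therefore expected to show a 1.0-fold lower number from compound 3 to compound 4 (0.01 log units; within the scatter), nothing beyond the scatter. The estimate for compound 4 is 310 10^-6 cm/s, with a range from 200 10^-6 cm/s to 450 10^-6 cm/s.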

Compound 4, apparent permeability: 317 10^-6 cm/s
For compound 4 the middle estimate is 1.0-fold (0.01 log units) below the measured one; the measured number falls inside the stated range.
By their numbers in this assay, from the lowest: compounds 2, 1, 3 and 4 (each within the scatter of the next).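

In this assay the exchange on this oxygen gives no change at the digits printed from compound 3 to compound 4 (within the scatter) and chloro in place of fluoro on an aromatic carbon gives no change at the digits printed from compound 1 to compound 4 (within the scatter) so that a third aryl ether ring, now carrying chloro, adds no step beyond the scatter at this position. Measured against the 4-(trifluoromethyl)phenyl on an aromatic carbon, 4-chlorophenoxy gives a 1.3-fold higher number from compound 2 to compound 4 (0.13 log units; within the scatter) and this also stays within the scatter. No measurement at hand explains these results. The compounds shown leave open whether an amine or a carboxylic acid on this ring would give a step beyond the scatter.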